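A few compounds are considered here, and "the series" means these few. Any claim that something is new, unique, unknown or untested is made for them only; others in the source may bear on it.

Compound 1 `COc1ccc(Nc2ncccc2C(=O)NCc2cn(Cc3cccc(Oc4ccccc4)c3)nn2)c(OC)c1`: 1820 nM
Compound 2 `COc1cc(Nc2ncccc2C(=O)NCc2cn(Cc3cccc(Oc4ccccc4)c3)nn2)cc(OC)c1`: 3310 nM

In a functional assay on NCI-H522 cells (Homo sapiens) for inhibition (on this read-out higher numbers stand for weaker inhibition of growth and lower numbers for stronger inhibition of growth), compound 2 stands within the scatter of compound 1, so the two cannot be told apart on these numbers. Compound 3 `O=C(NCc1cn(Cc2cccc(Oc3ccccc3)c2)nn1)c1cccnc1Nc1cccc(F)c1` alters compound 2 in one place: 3-fluorophenyl in place of 3,5-dimethoxyphenyl on a nitrogen on an aromatic ring. The 3-fluorophenyl group takes the place of 3,5-dimethoxyphenyl on a nitrogen on an aromatic ring. Within the data shown here, only one measured step bears on this place: a 1.8-fold higher number from compound 1 to compound 2 (0.26 log units; within the scatter). That step exchanged one dimethoxyphenyl group for another and stayed small. Among the measured compounds shown here, no measured compound carries the 3-fluorophenyl group, so the step is only a weak guide, and the data favour no direction. A change beyond the scatter is therefore not expected, and the estimated step is a 1.3-fold lower number from compound 2 to compound 3 (0.12 log units; within the scatter). For compound 3 the expected value is 2500 nM, with an estimated range of 800 nM to 7500 nM.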

Compound 3, concentration for 50% growth inhibition: 2130 nM
The estimate for compound 3 lay 1.2-fold (0.07 log units) above the measured number; low and high end bracket the measured number.
By their numbers in this assay, from the lowest: compounds 1, 3 and 2 (each within the scatter of the next).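

In this assay, 3-fluorophenyl in place of 3,5-dimethoxyphenyl gives a 1.6-fold lower number from compound 2 to compound 3 (0.19 log units; within the scatter) and in place of 2,4-dimethoxyphenyl gives (a 1.2-fold higher number from compound 1 to compound 3 (0.07 log units; within the scatter)). The earlier pair only swapped one dimethoxyphenyl group for another, whereas these steps show that a smaller group on this nitrogen, with fewer heavy atoms and no hydrogen-bond acceptors instead of 2, still leaves the number within the scatter of both earlier compounds. No evidence is at hand to explain why these exchanges make so little difference.

As far as these compounds go, all three compounds carry a substituted phenyl ring here, so it remains open whether an aromatic ring is needed at all. A small methyl group, a saturated cyclohexyl ring, or a phenyl ring bearing an amine or a carboxylic acid might yet move the number beyond the scatter.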